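Two Single Changes on One Shared Core

A few compounds are considered here, and "the series" means these few. Any claim that something is new, unique, unknown or untested is made for them only; others in the source may bear on it.

Three compounds have been measured in a functional assay on SMMC-7721 cells (Homo sapiens) for cytotoxicity, read by MTT assay, with a stated time of 24 h; on this read-out lower numbers stand for stronger inhibition and higher numbers for weaker inhibition:
compound 1 `COc1cc(/C=C2\CN(S(=O)(=O)c3ccc(F)cc3)C/C(=C\c3ccccc3F)C2=O)cc(OC)c1OC` gives 6340 nM
compound 2 `COc1cc(/C=C2\CN(S(=O)(=O)c3ccc(F)cc3)C/C(=C\c3cccc([N+](=O)[O-])c3)C2=O)cc(OC)c1OC` gives 4900 nM
compound 3 `COc1cc(/C=C2\CN(S(=O)(=O)c3ccc(NC(C)=O)cc3)C/C(=C\c3ccccc3F)C2=O)cc(OC)c1OC` gives 3920 nM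

Compound 2 differs from compound 1 by 3-nitrophenyl in place of 2-fluorophenyl on a double-bonded chain carbon bound to a double-bonded ring carbon, and that change made a 1.3-fold lower number from compound 1 to compound 2 (0.11 log units; within the scatter). Compound 3 differs from compound 1 by acetamido in place of fluoro on an aromatic carbon, which made a 1.6-fold lower number from compound 1 to compound 3 (0.21 log units; within the scatter). Compound 4 `COc1cc(/C=C2\CN(S(=O)(=O)c3ccc(NC(C)=O)cc3)C/C(=C\c3cccc([N+](=O)[O-])c3)C2=O)cc(OC)c1OC` has not been measured. It differs from compound 3 by 3-nitrophenyl in place of 2-fluorophenyl on a double-bonded chain carbon bound to a double-bonded ring carbon, the same change that was seen between compound 1 and compound 2, and the two cores differ by acetamido in place of fluoro on an aromatic carbon. The expected step for compound 4 is a 1.3-fold lower number from compound 3 to compound 4 (0.12 log units; within the scatter), since the step expected here rests on a 1.3-fold lower number from compound 1 to compound 2 (0.11 log units; within the scatter) measured for the same change. Compound 4 is therefore estimated at 3000 nM, expected to fall between 1400 nM and 6500 nM.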

Compound 4, half-maximal inhibitory concentration: 1950 nM
Compound 4: the middle estimate sits 1.5-fold (0.19 log units) above what was measured; the range from low to high includes it.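

In this assay, 3-nitrophenyl in place of 2-fluorophenyl gave a 2.0-fold lower number from compound 3 to compound 4 (0.30 log units; within the scatter), and this step agrees with the one measured on the other core: the same change on two cores in this assay, a 1.3-fold lower number (0.11 log units; within the scatter) from compound 1 to compound 2 and a 2.0-fold lower number (0.30 log units; within the scatter) from compound 3 to compound 4, 1.6-fold (0.19 log units) apart, within the scatter of two such steps. Acetamido in place of fluoro gave a 2.5-fold lower number from compound 2 to compound 4 (0.40 log units; beyond the scatter), which also agrees with its earlier counterpart: the same change on two cores in this assay, a 1.6-fold lower number (0.21 log units; within the scatter) from compound 1 to compound 3 and a 2.5-fold lower number (0.40 log units; beyond the scatter) from compound 2 to compound 4, 1.6-fold (0.19 log units) apart, within the scatter of two such steps. Going by these compounds alone, each change therefore carried over between these two cores without a detectable difference, but this does not show that either change would behave the same way on any other core, and only the step from compound 2 to compound 4 lies beyond the scatter.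

The compounds shown leave open how an amine or a carboxylic acid in place of acetamido would read out. They also leave open whether either change would carry over to a core with hydroxy groups in place of the methoxy groups.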